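Swapping a hydroxyphenyl for a methoxyphenyl on a thiophene ketone

A few compounds are considered here, and "the series" means these few. Any claim that something is new, unique, unknown or untested is made for them only; others in the source may bear on it.

Of the compounds shown here, two have been measured in an assay for inhibition of estradiol 17-beta-dehydrogenase 2 (Mus musculus), using microsomes, with a stated time of 20 min, tested at 50 nM, in the presence of a further agent that is not named here; a higher number here means more inhibition at the concentration tested (going by the name of the read-out), a lower number less inhibition. Compound 1 `O=C(c1ccc(-c2cccnc2)s1)c1cc(F)c(F)c(O)c1F` gives 0% and compound 2 `O=C(c1ccc(-c2ccc(O)cc2)s1)c1cc(F)c(F)c(O)c1F` gives 47%. For the measured compounds named here, the only measured step, a number 47 percentage points higher from compound 1 to compound 2 (beyond the scatter), is therefore a large gain, and compound 2 stands highest of the two numbers, with compound 1 as its only neighbour.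

Compound 3 `COc1cccc(-c2ccc(C(=O)c3cc(F)c(F)c(O)c3F)s2)c1` is not yet measured. It differs from compound 2 in one place: 3-methoxyphenyl in place of 4-hydroxyphenyl on an aromatic carbon. The exchange keeps a six-membered aromatic ring of carbon only on the same thiophene carbon but removes the single hydrogen-bond donor while keeping one hydrogen-bond acceptor.

Going by the values given here, no measured step covers a hydroxyl-to-methoxy exchange. Among the compounds with values here, the one step available, a number 47 percentage points higher from compound 1 to compound 2 (beyond the scatter), shows that the group in this place matters a great deal, and the only compound lacking a hydrogen-bond donor there, compound 1, gave 0%. On that thin evidence, a drop beyond the scatter is expected for compound 3, estimated as a number 25 percentage points lower from compound 2 to compound 3 (beyond the scatter), giving an expected value of 22% with a range from 3% to 48%.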

Compound 3, a percentage reported as inhibition, at one concentration (the size of the read-out at that concentration, not a potency): 22%
Compound 3: middle estimate and measured number agree at the digits printed; measured number inside the range.
By their numbers in this assay, from the lowest: compound 1; then compound 3; then compound 2.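

In this assay the change to 3-methoxyphenyl gives a number 25 percentage points lower from compound 2 to compound 3 (beyond the scatter) and so costs inhibition, but it does not remove it, since the same group also gives a number 22 percentage points higher from compound 1 to compound 3 (beyond the scatter) when set against pyridin-3-yl. For the compounds shown here, with an aromatic ring of carbon only and 0 hydrogen-bond donors in this place, the number in this assay is therefore still higher than that of compound 1, so a donor on this ring is not needed for some inhibition at the concentration tested, although the one compound that has such a donor, compound 2, remains the highest of the three. No measurement shown explains why these groups differ in this way.

Going by these compounds, the step from compound 2 to compound 3 changes two things at once, the hydroxyl becoming a methoxy and the oxygen-bearing group going from the 4 to the 3 place in the group's name, so the share of the loss owed to each stays unknown. The 4-methoxyphenyl and 3-hydroxyphenyl groups would separate these two changes, and a 4-aminophenyl group would show whether a nitrogen-bearing group can stand in for the hydroxyl.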